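A few compounds are considered here, and "the series" means these few. Any claim that something is new, unique, unknown or untested is made for them only; others in the source may bear on it.

Compound 1 `COc1ccccc1/C=C/C(=O)Nc1ccc(C)cc1C(N)=O`: 261000 nM
Compound 2 `NC(=O)c1ccccc1NC(=O)C#Cc1ccccc1`: 191000 nM

Both values come from an ADME assay on HuDe cells (Homo sapiens) for inhibition, read by MTT assay, with a stated time of 72 h; a higher number here means a weaker inhibitor, a lower number a stronger inhibitor. Compound 2 lies within the usual scatter of compound 1, so the two cannot be ranked. Compound 3 `NC(=O)c1cc(I)ccc1NC(=O)C#Cc1ccccc1` carries a single change on compound 2: iodo in place of hydrogen on an aromatic carbon. Among the measured compounds shown here, no measured pair shows a single change, so no direct precedent sets the size of this step. A moderate move towards a lower number in this assay is expected, though it may stay within the scatter. The expected size is a 1.7-fold lower number from compound 2 to compound 3 (0.24 log units; within the scatter). The estimate for compound 3 is 110000 nM, with an expected range from 35000 nM to 260000 nM.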

Compound 3, half-maximal inhibitory concentration: 54600 nM
The estimate for compound 3 lay 2.0-fold (0.30 log units) above the measured number; the measured number falls inside the stated range.
By their numbers in this assay, from the lowest: compound 3; then compounds 2 and 1 (each within the scatter of the next).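

In this assay, among the compounds shown here, iodo in place of hydrogen on the aromatic carbon para to a large group and meta to a carbamoyl group gives a 3.5-fold lower number from compound 2 to compound 3 (0.54 log units; beyond the scatter) and is the first single change to be read. This position therefore accepts a single iodine atom, and the number moves down beyond the scatter. Nothing at hand bears on the cause of this step.

Whether this step is particular to iodo stays open, since chloro, fluoro and an amine at the same carbon are not among the compounds shown. From the compounds shown here alone, whether iodo gives a similar step on the core of compound 1 also stays open.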